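Removing the nitrile from the aryl on the core nitrogen

This account rests on a few compounds, and the source may have more. Where it says the series, first, only, none or still open, it means among the compounds named here.

Measured compounds:
compound 1, `COc1cccc(C(C)Sc2nc3c(cnn3C)c(=O)n2-c2ccccc2)c1`, 108 nM
compound 2, `CC(Sc1nc2c(cnn2C)c(=O)n1-c1ccccc1)c1cccc(F)c1`, 110 nM
compound 3, `CC(Sc1nc2c(cnn2C)c(=O)n1-c1ccc(C#N)cc1)c1ccccc1`, 3100 nM

In an assay on isolated protein for inhibition of retinal dehydrogenase 2 (Homo sapiens) (a lower number here means a stronger inhibitor, a higher number a weaker inhibitor), compound 3 stands highest of the three values, with compound 2 and compound 1 both far lower and beyond the scatter. For the measured compounds named here, the only measured step, a 1.0-fold higher number from compound 1 to compound 2 (0.01 log units; within the scatter), concerns a change on the other aromatic ring and does not bear on the change examined here. Compound 4, `CC(Sc1nc2c(cnn2C)c(=O)n1-c1ccccc1)c1ccccc1`, differs from compound 3 by hydrogen in place of cyano on an aromatic carbon. Compound 4 shares its aryl on the core nitrogen with compound 1 and compound 2 and differs from each of them only by one group on the benzylic ring; in this assay compound 1 gives 108 nM and compound 2 gives 110 nM. Going by the values given here, the nitrile thus appears to go together with the high number of compound 3, although no direct step confirms this. Compound 4 is therefore expected to show a large drop, a 21-fold lower number from compound 3 to compound 4 (1.32 log units; beyond the scatter), in this assay. The estimated value of compound 4 is 150 nM, within a range from 50 nM to 500 nM.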

Compound 4, half-maximal inhibitory concentration: 110 nM
The estimate for compound 4 lay 1.4-fold (0.13 log units) above the measured number; the measured number falls inside the stated range.
By their numbers in this assay, from the lowest: compounds 1, 2 and 4 (each within the scatter of the next); then compound 3.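

In this assay, the direct step, a 28-fold lower number from compound 3 to compound 4 (1.45 log units; beyond the scatter), ties the high number of compound 3 to the 4-cyanophenyl group: replacing it with phenyl, with all else unchanged, accounts for the whole gap. Hydrogen on the other aromatic ring also proves indistinguishable from fluoro, no change at the digits printed from compound 2 to compound 4 (within the scatter), and from methoxy, a 1.0-fold higher number from compound 1 to compound 4 (0.01 log units; within the scatter), so the three substituents on that ring cannot be told apart in this assay while the change at the nitrile stands beyond the scatter. Nothing available explains the size of the nitrile step.

The compounds shown leave open whether an amine or a carboxylic acid at this same place would stay near compound 4 or approach compound 3. They also leave open whether the nitrile would give a step of the same size with methoxy or fluoro on the other ring.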